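Cyclopropyl to methyl at the edge of the assay

This account rests on a few compounds, and the source may have more. Where it says the series, first, only, none or still open, it means among the compounds named here.

Of the compounds shown here, two have been measured in an ADME assay on a cell-free system (plasma, Homo sapiens) for protein binding; on this read-out higher numbers stand for a larger free fraction and lower numbers for a smaller free fraction. Compound 1 (`CC(C)Cc1ccc(-c2cn(C)c3cc(C(=O)NS(C)(=O)=O)ccc23)cc1`) gives 0.001. Compound 2 (`CC(C)COc1ncc(-c2cn(C)c3cc(C(=O)NS(=O)(=O)C4CC4)c(F)cc23)cc1Cl`) gives < 0.001, which is a limit of the assay and not a number. As far as these compounds go, compound 2 therefore stands at the limit of < 0.001 in this assay, at which 1 of the 2 values shown sits, so its true distance from any neighbour is unknown.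

Compound 3 (`CC(C)COc1ncc(-c2cn(C)c3cc(C(=O)NS(C)(=O)=O)c(F)cc23)cc1Cl`) departs from compound 2 by a single change, methyl in place of cyclopropyl on a sulfonyl sulfur. For the measured compounds named here, no measured pair shows this change, so only a loose expectation is possible: a small rise in this assay, or none beyond the scatter. The expectation leans on compound 1, which also carries methylsulfonyl and gives 0.001. The expected change is a number no lower from compound 2 to compound 3 (the limit leaves the size open). For compound 3 the estimated value is 0.001, with an expected range from 0.0005 to 0.003.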

Compound 3, unbound fraction: 0.001
Estimate against measurement, compound 3: no gap at the digits printed, and the stated range covers the measured number.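

Methyl in place of cyclopropyl on a sulfonyl sulfur now has its first measured pair, and in this assay the step reads: a number no lower from compound 2 to compound 3 (the limit leaves the size open). For the compounds shown here, the result for compound 2 is a limit of the assay and not a number, so the pair gives a direction and no size: the limit of < 0.001 in this assay, at which 1 of the 3 values shown sits. At this place, with the amide-type nitrogen as the other neighbour on the sulfur, the smaller group leaves the read-out no lower, which the earlier compounds could not show without such a pair.

As far as these compounds go, whether the same change would shift the read-out in a compound further from the limit remains open, since this single pair sits at the edge of this assay. Also open, from the compounds shown here alone, is what a longer chain, such as ethyl, or an amine would give on the same sulfonyl sulfur.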